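From hydroxy to chloro on a short amide chain

The source may hold more compounds than are shown below. What is called first, only, known or untested is meant among the compounds shown, and "the series" means these compounds.

Going by the values given here, in a functional assay on MGC-803 cells (Homo sapiens) for inhibition, read by MTT assay, with a stated time of 48 h (on this read-out lower numbers stand for stronger inhibition and higher numbers for weaker inhibition), compound 2 `COc1ccc(CN(C(=O)CO)c2cc(OC)c(OC)c(OC)c2)cc1O` gives 160 nM and holds the higher of the two known numbers, while compound 1 `CCCCC(=O)N(Cc1ccc(OC)c(O)c1)c1cc(OC)c(OC)c(OC)c1` gives 66 nM on the same core. Compound 3 `COc1ccc(CN(C(=O)CCl)c2cc(OC)c(OC)c(OC)c2)cc1O` carries chloro in place of hydroxy on a saturated chain carbon bound to a carbonyl carbon in all. Among the compounds with values here, only one measured step bears on this place, the modest 2.4-fold higher number from compound 1 to compound 2 (0.38 log units; beyond the scatter) that came with hydroxy replacing propyl. With hydroxy leaving again, a similarly modest move to a lower number is expected in this assay, although chloro is not propyl. The estimate is a 2.3-fold lower number from compound 2 to compound 3 (0.36 log units; beyond the scatter) in this read-out. For compound 3 the expected value is 70 nM with an estimated range from 25 nM to 200 nM around it.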

Compound 3, half-maximal inhibitory concentration: 84 nM
For compound 3 the middle estimate is 1.2-fold (0.08 log units) below the measured one; the measured number falls inside the stated range.
By their numbers in this assay, from the lowest: compounds 1, 3 and 2 (each within the scatter of the next, the first and the last beyond it).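

In this assay, replacing hydroxy with chloro gives a 1.9-fold lower number from compound 2 to compound 3 (0.28 log units; within the scatter) and replacing propyl with chloro gives a 1.3-fold higher number from compound 1 to compound 3 (0.10 log units; within the scatter) in the same core. Both steps lie within the usual scatter, so compound 3 cannot be ranked against compound 1 or compound 2, even though those two differ beyond it. Chloro at this chain carbon therefore gives a number that cannot be told apart from either neighbour, and nothing measured here explains this. From the compounds shown here alone, whether an amine, a carboxylic acid or a longer chain at this place would stay in the same range remains open.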